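The source may report more compounds than this note shows. Statements on the series, on what has been measured and on what is new or still open speak of the compounds shown alone.

Compound 2 `COc1ccc(/C=C/C(=O)c2ccc3c(c2)oc(=O)n3CN2CCN(c3ccccc3OC)CC2)cc1` holds the lower of the two numbers measured in a functional assay on K562 cells (Homo sapiens) for cytotoxicity, read by MTT assay, with a stated time of 72 h; a higher number here means a weaker inhibitor, a lower number a stronger inhibitor: compound 2 gives 12400 nM, while compound 1 `O=C(/C=C/c1ccccc1)c1ccc2c(c1)oc(=O)n2CN1CCN(Cc2ccccc2)CC1` gives 29500 nM. The two compounds differ in more than one place, so their values are shown side by side without a single step between them. Compound 3 `COc1ccc(/C=C/C(=O)c2ccc3c(c2)oc(=O)n3CN2CCN(Cc3ccccc3)CC2)cc1` differs from compound 2 by benzyl in place of 2-methoxyphenyl on an amine nitrogen in a ring. Compound 3 is expected to give a slightly higher number, a step in a 1.6-fold higher number from compound 2 to compound 3 (0.21 log units; within the scatter) that stays within the scatter. Compound 3 is therefore estimated at 20000 nM, ranging from 7000 nM to 60000 nM.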

Compound 3, half-maximal inhibitory concentration: 24200 nM
The estimate for compound 3 lay 1.2-fold (0.08 log units) below the measured number, within the range that was stated.
By their numbers in this assay, from the lowest: compounds 2, 3 and 1 (each within the scatter of the next, the first and the last beyond it).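

In this assay, benzyl in place of 2-methoxyphenyl on the amine nitrogen in the ring gives a 2.0-fold higher number from compound 2 to compound 3 (0.29 log units; within the scatter), so this position does not tell these two groups apart. Methoxy in place of hydrogen on an aromatic carbon gives a 1.2-fold lower number from compound 1 to compound 3 (0.09 log units; within the scatter) and likewise stays within the scatter, although compounds 1 and 2, which differ in both places, lie beyond it. Nothing available explains these numbers. Open, going by these compounds, is whether a methyl group or a hydroxyethyl chain on that nitrogen, with no aromatic ring, would move the number beyond the scatter.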